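Moving One Methoxy Group on the Ring Nitrogen Substituent

The source may report more compounds than this note shows. Statements on the series, on what has been measured and on what is new or still open speak of the compounds shown alone.

Compound 1 `COc1ccc(OC)c(N2C(=O)CSC2c2cccc(C(=O)NCCCCc3ccccc3)c2)c1` was tested in a functional assay on HOS-TE85 cells (Homo sapiens) for inhibition, read by CCK-8 assay, with a stated time of 72 h; a lower number here means a stronger inhibitor, a higher number a weaker inhibitor. Compound 1 gives only a limit there, > 1000 nM, not a number. Compound 2 `COc1ccccc1N1C(=O)CSC1c1cccc(C(=O)NCCCCN2C(=O)C=CC2=O)c1` also gives only a limit in this assay, > 1000 nM. Compound 3 `CC1SC(c2cccc(C(=O)NCCCCc3ccccc3)c2)N(c2cccc(C3CC3)c2)C1=O` gives 295 nM in this assay. Two of the three values therefore sit at the same boundary (the limit of > 1000 nM in this assay, at which 2 of the 3 values shown sit). Compound 4 `COc1ccc(N2C(=O)CSC2c2cccc(C(=O)NCCCCc3ccccc3)c2)c(OC)c1` is not yet measured. It differs from compound 1 in one place: 2,4-dimethoxyphenyl in place of 2,5-dimethoxyphenyl on an amide-type nitrogen in a ring. Within the data shown here, no measured pair differs in only one place, so the size of this step cannot be read from the data. Because compound 1 sits at the limit (the limit of > 1000 nM in this assay, at which 2 of the 3 values shown sit), the direction can only be guessed. Compound 4 is expected at 1500 nM, within a range from 400 nM to 6000 nM. The step that the limit leaves unreadable from compound 1 to compound 4 is expected to be small, in no firm direction.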

Compound 4, half-maximal inhibitory concentration: 90.4 nM
For compound 4 the middle estimate is 17-fold (1.22 log units) above the measured one; the whole stated range lies above it.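

Among these compounds, the atoms stay the same and only one methoxy group moves, yet in this assay 2,4-dimethoxyphenyl in place of 2,5-dimethoxyphenyl gives an at least 11-fold lower number from compound 1 to compound 4 (1.04 log units; beyond the scatter). The arrangement of groups on this ring, not just their number or kind, therefore matters greatly in this series. The full size of the step cannot be read because compound 1 gives only a limit: the limit of > 1000 nM in this assay, at which 2 of the 4 values shown sit.

Compounds 2 and 3 differ from compound 4 in more than one place, so they cannot show which methoxy group matters more. From the compounds shown here alone, it also remains open whether an ethoxy group or an amine could replace the methoxy group at its new place.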